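A chloro group on an inactive compound

This account rests on a few compounds, and the source may have more. Where it says the series, first, only, none or still open, it means among the compounds named here.

Measured so far:
compound 1 `CC(=O)SCCC(CCCCC(=O)O)SC(C)=O`: 10.3%
compound 2 `CC(=O)SCCC(CCCCC(=O)Nc1ccccc1)SC(C)=O`: "not active" (no number reported)

In a functional assay on Bel-7402 cells (Homo sapiens) for inhibition, read by MTT assay, with a stated time of 24 h, tested at 0.1 ug/mL (on this read-out higher numbers stand for more inhibition of growth at the one concentration tested and lower numbers for less inhibition of growth), compound 2 is reported as "not active" (no number reported), so it has no single number to start from. Compound 3 `CC(=O)SCCC(CCCCC(=O)Nc1ccccc1Cl)SC(C)=O` differs from it in one place, chloro in place of hydrogen on an aromatic carbon, ortho to a large group. Going by the values given here, no measured pair shows what this change does. The expectation is therefore a small step upward at most, with none beyond the usual scatter. For compound 3 the estimated inhibition of growth is 8%, with an expected range of 0% to 20%.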

Compound 3, percent growth inhibition at one concentration: 6.61%
Estimate against measurement, compound 3: 1.4 percentage points above; low and high end bracket the measured number.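

In this assay, compound 3 carries a number where compound 2 has none, so the step between these two cannot be read. Putting (2-chlorophenyl)amino in place of hydroxy on the carbonyl carbon gives a number 3.7 percentage points lower from compound 1 to compound 3 (within the scatter), so compound 1 and compound 3 cannot be told apart on this read-out. Nothing available explains either result. Still open, on these data alone, is whether a bromo, methyl or methoxy group in place of this chloro would read any differently in this assay.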